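Adding a 4-Fluorobenzyl Group to Compound 1

A few compounds are considered here, and "the series" means these few. Any claim that something is new, unique, unknown or untested is made for them only; others in the source may bear on it.

Three compounds have been measured in a functional assay on MOLT-4 cells (Homo sapiens), with a stated time of 72 h; on this read-out lower numbers stand for stronger inhibition and higher numbers for weaker inhibition:
Compound 1 `O=C1Nc2ccc(Cl)cc2/C1=N/NC(=S)Nc1ccc(Cl)cc1` gives 64000 nM.
Compound 2 `Cc1ccc(NC(=S)N/N=C2\C(=O)Nc3ccc(Br)cc32)cc1` gives 4900 nM.
Compound 3 `O=C1Nc2ccc(F)cc2/C1=N/NC(=S)Nc1ccc(Cl)cc1` gives 14000 nM.

Among these three, compound 1 stands at the highest number, that is, the weakest inhibition of the set. For the measured compounds named here, its nearest neighbour is compound 3, and the only single-point step recorded here runs between them: a 4.6-fold lower number from compound 1 to compound 3 (0.66 log units; beyond the scatter). Compound 2 lies further away still, at a lower number.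

Compound 4 `O=C1/C(=N\NC(=S)Nc2ccc(Cl)cc2)c2cc(Cl)ccc2N1Cc1ccc(F)cc1` differs from compound 1 in one place: 4-fluorobenzyl in place of hydrogen on an amide-type nitrogen in a ring. Going by the values given here, no measured step touches this position; the one recorded step, from compound 1 to compound 3, concerns a halogen on an aromatic carbon and says nothing about what a group on the ring nitrogen does. The expectation therefore rests on little. Compound 4 is expected to give 25000 nM in this assay, with a range from 6000 nM to 100000 nM. This corresponds to an expected 2.6-fold lower number from compound 1 to compound 4 (0.41 log units; beyond the scatter). The downward lean is chosen because compound 1 sits at 64000 nM, the top of what has been seen so far, leaving more room below than above.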

Compound 4, half-maximal inhibitory concentration: 48000 nM
Beside the measured number, compound 4's estimate is 1.9-fold (0.28 log units) below it; the range from low to high includes it.
By their numbers in this assay, from the lowest: compound 2; then compound 3; then compounds 4 and 1 (each within the scatter of the next).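

Replacing the amide hydrogen of compound 1 with 4-fluorobenzyl gives a 1.3-fold lower number from compound 1 to compound 4 (0.12 log units; within the scatter) in this assay, so the two compounds cannot be told apart on this read-out. At this weak level of inhibition, then, neither the hydrogen on this ring nitrogen nor the added aromatic ring shows any clear influence, at least on the core of compound 1. Nothing measured here bears on why the number stays within the scatter.

On these data alone, it remains open whether a methyl group, an unsubstituted benzyl or a chain ending in an amine on this nitrogen would shift the number in either direction. It is also unknown whether 4-fluorobenzyl would behave the same way on compound 2 or compound 3, which start from lower numbers.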